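Removing the Nitrogen Methyl in a Cell-Growth Series

This account rests on a few compounds, and the source may have more. Where it says the series, first, only, none or still open, it means among the compounds named here.

Compound 1 `c1cc(N2CCCCC2)nc(Nc2ccc(Oc3ncnc4sccc34)cc2)n1`: 66.3%
Compound 2 `CN(c1ccc(Oc2ncnc3ccsc23)cc1)c1nccc(N2CCc3ccccc3C2)n1`: 58.3%
Compound 3 `CN(c1ccc(Oc2ncnc3sccc23)cc1)c1nccc(N2CCCCC2)n1`: 52.2%

Three compounds were examined in a functional assay on HCT-116 cells (Homo sapiens) for inhibition, read by MTT assay, with a stated time of 72 h, tested at 20 uM; on this read-out lower numbers stand for less inhibition and higher numbers for more inhibition at the one concentration tested (going by the name of the read-out). In this assay compound 1 gives 66.3%, compound 2 gives 58.3% and compound 3 gives 52.2%. Compound 2 sits between the other two, and its distances to both compound 3 and compound 1 lie within the scatter, so no order among these three is claimed from compound 2 alone.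

Compounds 3 and 1 share a core and differ in one place: hydrogen in place of methyl on a nitrogen on an aromatic ring. That change made a step of a number 14.1 percentage points higher from compound 3 to compound 1 (beyond the scatter). The cores of compound 2 and compound 3 differ from each other, but that difference is not broken down here.

Compound 4 `c1ccc2c(c1)CCN(c1ccnc(Nc3ccc(Oc4ncnc5ccsc45)cc3)n1)C2` has not yet been measured in this assay. It is related to compound 2 by the same change that relates compound 3 to compound 1: hydrogen in place of methyl on a nitrogen on an aromatic ring. Because the step of a number 14.1 percentage points higher from compound 3 to compound 1 (beyond the scatter) lay beyond the scatter, the expectation is that the same change on the core of compound 2 gives a step of about the same size, so the estimated step from compound 2 to compound 4 is a number 13.7 percentage points higher from compound 2 to compound 4 (beyond the scatter). This rests on a single precedent, and compound 2 starts from a value within the scatter of compound 3, so the estimate is kept broad. Compound 4 is accordingly expected to give about 72% in this assay, with a plausible range from 60% to 84%.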

Compound 4, a percentage reported as inhibition, at one concentration (the size of the read-out at that concentration, not a potency): 40.9%
The estimate for compound 4 lay 31.1 percentage points above the measured number; measured number outside the range, below it.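

In this assay, the same change gave a number 17.4 percentage points lower from compound 2 to compound 4 (beyond the scatter) and so did not carry over from the core of compound 3 to the core of compound 2. Set side by side, the two steps point in opposite directions and their gap is larger than repeated measurements would explain: the same change on two cores in this assay, a number 14.1 percentage points higher (beyond the scatter) from compound 3 to compound 1 and a number 17.4 percentage points lower (beyond the scatter) from compound 2 to compound 4, 31.5 percentage points apart, beyond the scatter of two such steps. This shows that, among these four compounds, the outcome of hydrogen in place of methyl on a nitrogen on an aromatic ring differs with the core that carries it, so a step seen on one core gave no safe guide to the other; it does not show which of the differences between the two cores is responsible, and two pairs give no rule for any further core.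

The compounds shown leave open whether an ethyl group or a longer chain on that same nitrogen would follow the step seen on one core, the other, or neither. They also leave open how the change would behave on a core carrying a morpholine or an open-chain amine, and each reading here comes from a single concentration rather than from a potency.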